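The source may report more compounds than this note shows. Statements on the series, on what has been measured and on what is new or still open speak of the compounds shown alone.

Working notes on the series. Compound 3 `COc1ccc(-c2cc(C(=O)/C=C/c3ccc(Cl)cc3)nc3cc(-c4ccccc4)nn23)cc1OC` gives 22000 nM in a functional assay on A549 cells (Homo sapiens) for antiproliferative activity, read by MTT assay, with a stated time of 24 h; a lower number here means a stronger inhibitor, a higher number a weaker inhibitor; among the three numbers in hand it is the second highest, with both neighbours inside the scatter. Compound 1 `COc1ccc(/C=C/C(=O)c2cc(-c3ccc(OC)c(OC)c3)n3nc(-c4ccccc4)cc3n2)cc1` gives 19300 nM in this assay, and compound 2 `COc1cc(-c2cc(C(=O)/C=C/c3ccc(Cl)cc3)nc3cc(-c4ccccc4)nn23)cc(OC)c1OC` gives 23800 nM. The step of a 1.1-fold higher number from compound 1 to compound 3 (0.06 log units; within the scatter) is a chloro in place of methoxy on an aromatic carbon; the step of a 1.1-fold lower number from compound 2 to compound 3 (0.03 log units; within the scatter) is a hydrogen in place of methoxy on an aromatic carbon. Neither moves the number beyond the scatter.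

Compound 4 `COc1ccc(C(=O)/C=C/c2cc(-c3ccc(OC)c(OC)c3)n3nc(-c4ccccc4)cc3n2)cc1` is next, not yet measured. Against compound 3 the change is 2-((4-methoxyphenyl)carbonyl)ethenyl in place of (2-(4-chlorophenyl)ethenyl)carbonyl on an aromatic carbon. Two things happen at once: the carbonyl and the ethenyl swap places within the linker, and a methoxy stands in place of chloro on an aromatic carbon. Among the measured compounds shown here, only the second part has a precedent, in a 1.1-fold higher number from compound 1 to compound 3 (0.06 log units; within the scatter); the swap of carbonyl and ethenyl has no precedent among the measured compounds. Because a 1.1-fold higher number from compound 1 to compound 3 (0.06 log units; within the scatter) stays within the scatter, no shift beyond the scatter is expected from the methoxy alone, and the expected step of no change at the digits printed from compound 3 to compound 4 (within the scatter) is therefore set at none beyond the scatter, with a wide range to cover the unprecedented swap. The estimate for compound 4 is 22000 nM, between 7000 nM and 70000 nM.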

Compound 4, half-maximal inhibitory concentration: 11900 nM
Compound 4: the middle estimate sits 1.8-fold (0.27 log units) above what was measured; the range from low to high includes it.
By their numbers in this assay, from the lowest: compounds 4, 1, 3 and 2 (each within the scatter of the next).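

The swap of carbonyl and ethenyl within the linker can be read on its own, with the methoxy kept, as a 1.6-fold lower number from compound 1 to compound 4 (0.21 log units; within the scatter), so in this assay this aromatic carbon of the core accepts either orientation of the linker without a shift beyond the scatter. The combined change, with the swap and a methoxy in place of chloro together, gives a 1.8-fold lower number from compound 3 to compound 4 (0.27 log units; within the scatter), which is also within the scatter, and so the earlier finding that the methoxy and chloro exchange moves nothing beyond the scatter now extends to a pair that also differs in linker orientation. No measurement accompanies these numbers that could account for them or for the small differences among them.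

The compounds shown leave open whether anything at this position can move the number beyond the scatter, since every change here keeps a linker with a carbonyl and an ethenyl ending in a para-substituted phenyl ring. A saturated two-carbon chain in place of the ethenyl, an amide in place of the carbonyl, or an amine or a carboxylic acid on the terminal aromatic ring would test that directly.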